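A few compounds are considered here, and "the series" means these few. Any claim that something is new, unique, unknown or untested is made for them only; others in the source may bear on it.

Working notes on the series. The shared core carries a propanamide in compound 1 `CCC(=O)Nc1c(C(O)(C(F)(F)F)C(F)(F)F)ccc2ccccc12` and a benzamide in compound 2 `O=C(Nc1c(C(O)(C(F)(F)F)C(F)(F)F)ccc2ccccc12)c1ccccc1Cl`. Among the compounds with values here, in an assay on LtK cells with ATP-sensitive inward rectifier potassium channel 11 (Homo sapiens) as the target (a higher number here means that more compound is needed for the effect, a lower number that less compound is needed), compound 1 gives 15 nM, and compound 2 gives 2040 nM, the highest of the two numbers measured so far; the only step on record, a 140-fold higher number from compound 1 to compound 2 (2.13 log units; beyond the scatter), is large and comes from 2-chlorophenyl in place of ethyl on a carbonyl carbon. Compound 3 `O=C(Nc1c(C(O)(C(F)(F)F)C(F)(F)F)ccc2ccccc12)c1ccc(Br)cc1` keeps the benzamide and changes the aryl group: 4-bromophenyl in place of 2-chlorophenyl on a carbonyl carbon. Within the data shown here, no measured step bears directly on this change; the one step available concerns the exchange of an alkyl group for an aryl group, not the exchange of one substituted aryl group for another, so it gives only a loose frame. The expectation for compound 3 in this assay is therefore a number near that of compound 2, with no step beyond the scatter expected, a 1.1-fold lower number from compound 2 to compound 3 (0.05 log units; within the scatter), and a wide range to either side. Compound 3 is estimated at 1800 nM, between 350 nM and 9000 nM.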

Compound 3, half-maximal effective concentration: 47 nM
Beside the measured number, compound 3's estimate is 38-fold (1.58 log units) above it; measured number below the stated range.
By their numbers in this assay, from the lowest: compound 1; then compound 3; then compound 2.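

In this assay an aryl group on this carbonyl carbon does not in itself bring a large rise in the number: the series shows a 43-fold lower number from compound 2 to compound 3 (1.64 log units; beyond the scatter) for 4-bromophenyl in place of 2-chlorophenyl, although the two groups match in heavy-atom count, aromatic ring and absence of hydrogen-bond donors and acceptors. Measured against the ethyl group, 4-bromophenyl gives only a 3.1-fold higher number from compound 1 to compound 3 (0.50 log units; beyond the scatter), a modest step that still lies beyond the scatter, so the large rise seen earlier holds for 2-chlorophenyl and not for both aryl groups shown. The data on hand offer no explanation for so wide a gap between the two aryl groups.

The step from 2-chlorophenyl to 4-bromophenyl changes both the halogen and its place on the ring, so the compounds shown cannot assign the step to either change, and a 4-chlorophenyl or 2-bromophenyl group would be needed to separate them. Also open, from the compounds shown here alone, is how an unsubstituted phenyl group, a longer alkyl chain or a chain carrying an amine would stand on this carbonyl carbon relative to the ethyl and 4-bromophenyl groups.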